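The compounds below may be only part of what the source reports. "The series", "measured", "known", "first", "only" and "open" are said of these compounds alone.

Compound 1, `C#CCCO[C@@H]1C=CC(=O)[C@@H](CO)O1`, carries a but-3-yn-1-yl chain. Among the measured compounds shown here, in a functional assay on NCI-H292 cells (Homo sapiens) for inhibition, read by MTT assay, with a stated time of 72 h (a higher number here means a weaker inhibitor, a lower number a stronger inhibitor), compound 1 gives 12700 nM, the higher of the two numbers measured so far; compound 2, `O=C1C=C[C@@H](OCc2ccccc2)O[C@@H]1CO`, gives 3800 nM, a lower number by more than the usual scatter. Compound 3, `CCO[C@@H]1C=CC(=O)[C@@H](CO)O1`, differs from compound 1 by hydrogen in place of ethynyl on a saturated chain carbon, two bonds along the chain from an oxygen on a saturated carbon. For the measured compounds named here, no measured pair shows what such a change does, so in this assay only a small step is expected, if any, perhaps toward a slightly higher number. The expected step is a 1.2-fold higher number from compound 1 to compound 3 (0.07 log units; within the scatter). Compound 3 is therefore estimated at 15000 nM, in a range from 5000 nM to 45000 nM.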

Compound 3, half-maximal inhibitory concentration: 18000 nM
Estimate against measurement, compound 3: 1.2-fold (0.08 log units) below; the measured number falls inside the stated range.
By their numbers in this assay, from the lowest: compound 2; then compounds 1 and 3 (each within the scatter of the next).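

In this assay, cutting but-3-yn-1-yl back to ethyl gives a 1.4-fold higher number from compound 1 to compound 3 (0.15 log units; within the scatter), which lies within the usual scatter. Among the compounds shown here, this is the first measured reading at this position, and it shows that in this pair the ethynyl end of the chain can go without a change that can be told from the scatter. No measurement shown here offers an explanation for this result. The compounds shown leave open what an amine or a carboxylic acid at the end of this chain would do, and whether a longer saturated chain would move the number.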